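Methylsulfanyl for Azido on the Shared Core

A few compounds are considered here, and "the series" means these few. Any claim that something is new, unique, unknown or untested is made for them only; others in the source may bear on it.

The series is read in a functional assay on EL4 cells (Mus musculus) for inhibition, tested at 100 uM; on this read-out lower numbers stand for less inhibition and higher numbers for more inhibition at the one concentration tested (going by the name of the read-out). Compound 1 `OC[C@H]1OC(n2cnc3c(NCc4ccccc4)nccc32)[C@H](O)[C@@H]1O` gives 5% in this assay. Compound 2 `[N-]=[N+]=Nc1[nH]ccc2ncnc1-2` returns in this assay only a limit of the assay, < 5%, and no number. Compound 2 thus stands at the limit of < 5% in this assay, at which 1 of the 2 values shown sits, the lowest point among the numbers shown, and compound 1 sits close to it; both readings are within the usual scatter of each other, so no order between them is claimed. Going by the values given here, no step between measured compounds is available, and the two values together show only two low readings.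

Compound 3 `CSc1[nH]ccc2ncnc1-2` is compound 2 with one change: methylsulfanyl in place of azido on an aromatic carbon. The step of a number no lower from compound 2 to compound 3 (the limit leaves the size open) is expected to lie inside the usual scatter, in neither direction, because compound 2 already reads at the limit of < 5% in this assay, at which 1 of the 2 values shown sits. Compound 3 is expected to give 5% in this assay, with a range from 0% to 15%, and the result may again come back as a limit only.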

Compound 3, a percentage reported as inhibition, at one concentration (the size of the read-out at that concentration, not a potency): < 5%
Compound 3 ended at the assay's limit (the forecaster's own chance of this, stated with the estimate: 50%); the middle value sits exactly at the limit.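

In this assay compound 3 returns only a limit of the assay, < 5%. Compound 2 also returns only a limit, so no step can be read between compound 2 and compound 3. The compounds shown leave open whether methylsulfanyl and azido on the shared core differ at all in this assay.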